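This account rests on a few compounds, and the source may have more. Where it says the series, first, only, none or still open, it means among the compounds named here.

In a functional assay on HCT-116 cells (Homo sapiens) for cytotoxicity, with a stated time of 72 h (a higher number here means a weaker inhibitor, a lower number a stronger inhibitor), compound 1 `COc1ccc(/C(=C/c2ccc(OC)c(O)c2)c2cc(OC)c(OC)c(OC)c2)cc1` gives > 10000 nM, which is a limit of the assay and not a number. Compound 4 `COc1ccc(/C=C(/c2ccc(OC)c(O)c2)c2cc(OC)c(OC)c(OC)c2)cc1O` differs from it by hydroxy in place of hydrogen on an aromatic carbon, ortho to a methoxy group, which turns 4-methoxyphenyl into 3-hydroxy-4-methoxyphenyl. Two measured neighbours give a guide. Compound 2 `COc1ccc(/C=C(\c2cc(OC)c(OC)c(OC)c2)c2ccc3ccccc3c2)cc1O` gives 8000 nM and compound 3 `COc1ccc(/C=C(/c2ccc(OC)c(F)c2)c2cc(OC)c(OC)c(OC)c2)cc1O` gives 8000 nM. The nearest parallel is the swap of fluoro for hydrogen, an at least 1.2-fold lower number from compound 1 to compound 3 (0.09 log units; that floor lies within the scatter). Replacing the ring altogether gives a similar picture, an at least 1.2-fold lower number from compound 1 to compound 2 (0.09 log units; that floor lies within the scatter), and the two neighbours do not separate, no change at the digits printed from compound 2 to compound 3 (within the scatter). Neither step from compound 1 is shown to exceed the scatter, so only a small move toward a lower number is expected for the new hydroxy, with the reading possibly staying at the limit. The expected step is an at least 1.6-fold lower number from compound 1 to compound 4 (0.22 log units; that floor lies within the scatter). For compound 4 the estimated value is 6000 nM, with an expected range of 1500 nM to 12000 nM.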

Compound 4, half-maximal inhibitory concentration: 5000 nM
Beside the measured number, compound 4's estimate is 1.2-fold (0.08 log units) above it; low and high end bracket the measured number.
By their numbers in this assay, from the lowest: compounds 4, 2 and 3 (each within the scatter of the next). At a limit, above all of these: compound 1.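

In this assay, within the data shown here, hydroxy in place of hydrogen gives an at least 2.0-fold lower number from compound 1 to compound 4 (0.30 log units; that floor lies within the scatter), which is the first step at this position that ends in a measured number on the side of the new group. On these data alone, compound 1 stands at a limit of the assay and not at a number, so the true size of this step stays unknown: the limit of > 10000 nM in this assay, at which 1 of the 4 values shown sits. Hydroxy in place of fluoro gives a 1.6-fold lower number from compound 3 to compound 4 (0.20 log units; within the scatter), and the whole 3-hydroxy-4-methoxyphenyl group in place of naphthalen-2-yl gives a 1.6-fold lower number from compound 2 to compound 4 (0.20 log units; within the scatter), so neither swap sets these groups apart.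

As far as these compounds go, what stays open is whether any group at this place can move the number clearly beyond the scatter. An amine or a longer ether such as ethoxy in place of the hydroxy would show whether the hydroxy itself matters or whether other groups serve equally well.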